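Compound 3 in the Tail Flick Test: An Estimate

The source may hold more compounds than are shown below. What is called first, only, known or untested is meant among the compounds shown, and "the series" means these compounds.

Measured so far:
compound 1, `N=C(N)NCCC[C@H](NC(=O)CN(c1nc(Cl)nc2[nH]cnc12)C1CC1)C(=O)O`: 51%
compound 2, `N=C(N)NCCC[C@H](NC(=O)CN(c1nc(Cl)nc2[nH]cnc12)C1CC1)C(=O)OCc1ccccc1`: 30.6%

Both numbers come from a functional assay on the whole organism (Tail, strain ICR) with Mus musculus as the target, in the tail flick test, with a stated time of 60 min, at a dose of 25 umol/kg by the oral route; a higher number here means a stronger effect of the compound at the dose given, a lower number a weaker effect. Among the compounds with values here, compound 2 stands lowest of the two; its only neighbour is compound 1, and the one measured step, a number 20.4 percentage points lower from compound 1 to compound 2 (beyond the scatter), separates them, a change of benzyl in place of hydrogen on an oxygen next to a carbonyl group.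

Compound 3, `NC(=O)CC[C@H](NC(=O)CN(c1nc(Cl)nc2[nH]cnc12)C1CC1)C(=O)OCc1ccccc1`, has not yet been measured. It differs from compound 2 by a group of 3 heavy atoms (1 carbon, 1 nitrogen, 1 oxygen; no ring) in place of a group of 5 heavy atoms (2 carbon, 3 nitrogen; no ring), on a saturated chain carbon, three bonds along the chain from an amide-type nitrogen and a carbonyl carbon. Within the data shown here, no measured step touches this part of the molecule: the single known step concerns the oxygen next to the carbonyl group, a different place, so it gives no guide to what this exchange does. The expectation therefore rests on the value of compound 2 as the starting point, with a wide band of uncertainty around it.

Compound 3 is expected to give 25%, in a range from 5% to 45%. This estimate means a step of a number 5.6 percentage points lower from compound 2 to compound 3 (within the scatter), expected to stay within the usual scatter rather than mark a clear change in either direction.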

Compound 3, a percentage reported as activity, at one dose (the size of the read-out at that dose, not a potency): 33.1%
Compound 3: middle estimate off by 8.1 percentage points, on the low side; low and high end bracket the measured number.
By their numbers in this assay, from the lowest: compounds 2 and 3 (each within the scatter of the next); then compound 1.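

In this assay, putting carbamoyl in place of the group of 5 heavy atoms (2 carbon, 3 nitrogen; no ring), on a saturated chain carbon, three bonds along the chain from an amide-type nitrogen and a carbonyl carbon, gives a number 2.5 percentage points higher from compound 2 to compound 3 (within the scatter) while the benzyl group stays in place. Within the data shown here, this is the first look at this part of the molecule, and at this one dose the read-out does not separate the two groups, even though the count falls from 3 hydrogen-bond donors to 1 hydrogen-bond donor. The larger group is therefore not needed to keep this level of effect in the benzyl series, but no data on hand explain this result.

From the compounds shown here alone, it remains open whether an amine or a carboxylic acid in place of carbamoyl on the same saturated chain carbon, or a longer chain carrying carbamoyl, would also leave the read-out unchanged. Going by these compounds, it is also open whether carbamoyl would match the larger group when hydrogen replaces benzyl on the oxygen, the change that did shift the read-out beyond the scatter.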